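Notes on the series: compound 2 to compound 3

The compounds below may be only part of what the source reports. "The series", "measured", "known", "first", "only" and "open" are said of these compounds alone.

Among the compounds with values here, in a functional assay (aorta) with Oryctolagus cuniculus as the target (on this read-out lower numbers stand for tighter binding and higher numbers for weaker binding), compound 2 `COc1cc(OCCCN2CCC(C(c3ccc(F)cc3)c3ccc(F)cc3)CC2)ccc1C(C)=O` gives 3.16 nM, the lowest of the two numbers measured so far. The nearest is compound 1 `COc1cc(C(C)=O)ccc1OCCCN1CCC(C(c2ccc(C)cc2)c2ccc(C)cc2)CC1`, which in this assay gives 15.9 nM, a gap beyond the usual scatter. Within the data shown here, no pair measured so far differs in only one place, so no single step can be read from the two values directly.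

Compound 3 `Fc1ccc(C(c2ccc(F)cc2)C2CCN(CCCOc3cccc4ccccc34)CC2)cc1` is not yet measured. It differs from compound 2 as follows: naphthalen-1-yl in place of 4-acetyl-3-methoxyphenyl on an oxygen on a saturated carbon, that is, 4-acetyl-3-methoxyphenoxy becomes (naphthalen-1-yl)oxy. Among the measured compounds shown here, nothing measured so far shows what replacing this group does in this assay, so the direction is open.

The expectation is for a modest weakening in this assay, with the step from compound 2 to compound 3 estimated at a 2.5-fold higher number from compound 2 to compound 3 (0.40 log units; beyond the scatter). Compound 3 is therefore expected to give about 8 nM, within a range from 2 nM to 32 nM.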

Compound 3, dissociation constant: 5.01 nM
Estimate against measurement, compound 3: 1.6-fold (0.20 log units) above; low and high end bracket the measured number.
By their numbers in this assay, from the lowest: compounds 2 and 3 (each within the scatter of the next); then compound 1.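

In this assay the change from 4-acetyl-3-methoxyphenoxy to (naphthalen-1-yl)oxy gives a 1.6-fold higher number from compound 2 to compound 3 (0.20 log units; within the scatter) and so does not separate the two groups at this place, on an oxygen on a saturated carbon. The entering group has 0 hydrogen-bond acceptors and 2 six-membered aromatic rings of carbon only, so in this pair neither the acetyl nor the methoxy group is needed to keep the number within the scatter. No supporting data bear on why these two groups read alike.

Still open, as far as these compounds go, is whether an amine or a carboxylic acid on the naphthalen-1-yl group would keep the number in this range. Also open, from the compounds shown here alone, is whether a longer chain on the oxygen would shift it, and whether the same replacement would read alike on the core of compound 1.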